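A few compounds are considered here, and "the series" means these few. Any claim that something is new, unique, unknown or untested is made for them only; others in the source may bear on it.

Measured compounds:
compound 1, `CCCCc1cn(C[C@H](O)[C@H]2OC(=O)C(OCc3ccccc3)=C2OCc2ccccc2)nn1`; in a functional assay on A549 cells (Homo sapiens) for antiproliferative activity, read by MTT assay, with a stated time of 72 h (a lower number here means a stronger inhibitor, a higher number a weaker inhibitor), compound 1 gives 28600 nM.
compound 2, `O=C1O[C@H]([C@@H](O)Cn2cc(CNS(=O)(=O)c3ccc(F)cc3)nn2)C(OCc2ccccc2)=C1OCc1ccccc1`; in this assay compound 2 gives 22500 nM.
compound 3, `Cc1ccc(S(=O)(=O)NCc2cn(C[C@H](O)[C@H]3OC(=O)C(OCc4ccccc4)=C3OCc3ccccc3)nn2)cc1`; in this assay compound 3 gives 16800 nM.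

Compound 3 gives the lowest number of the three, but the steps of a 1.3-fold lower number from compound 2 to compound 3 (0.13 log units; within the scatter) and a 1.7-fold lower number from compound 1 to compound 3 (0.23 log units; within the scatter) both fall within the scatter, so the three compounds cannot be separated. Compound 4, `O=C1O[C@H]([C@@H](O)Cn2cc(CNS(=O)(=O)c3ccc(Cl)cc3F)nn2)C(OCc2ccccc2)=C1OCc1ccccc1`, differs from compound 3 in one place: 4-chloro-2-fluorophenyl in place of 4-methylphenyl on a sulfonyl sulfur. The measured steps bearing on this position are a 1.3-fold lower number from compound 1 to compound 2 (0.10 log units; within the scatter), a 1.7-fold lower number from compound 1 to compound 3 (0.23 log units; within the scatter) and a 1.3-fold lower number from compound 2 to compound 3 (0.13 log units; within the scatter), all within the scatter; replacing propyl by either sulfonamide, or exchanging fluoro for methyl on the aromatic carbon, left the number essentially unchanged. Nothing measured in this series suggests that a further change of substitution on the aryl of the sulfonyl would move this assay beyond the scatter. The step expected is a 1.1-fold higher number from compound 3 to compound 4 (0.03 log units; within the scatter), that is no change beyond the scatter. Compound 4 is therefore estimated at 18000 nM, with a range from 9000 nM to 36000 nM.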

Compound 4, half-maximal inhibitory concentration: 39100 nM
Compound 4: middle estimate off by 2.2-fold (0.34 log units), on the low side; measured number outside the range, above it.
By their numbers in this assay, from the lowest: compounds 3, 2, 1 and 4 (each within the scatter of the next, the first and the last beyond it).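

In this assay, going by these compounds alone, the aryl on the sulfonyl sulfur is the first place where a single change clears the scatter: 4-chloro-2-fluorophenyl in place of 4-methylphenyl gives a 2.3-fold higher number from compound 3 to compound 4 (0.37 log units; beyond the scatter) and counts as a modest step. The same group shows a 1.7-fold higher number from compound 2 to compound 4 (0.24 log units; within the scatter) against 4-fluorophenyl and a 1.4-fold higher number from compound 1 to compound 4 (0.14 log units; within the scatter) against propyl, both within the scatter, so the sensitivity of this position rests on one pair of compounds. No measurement bears on what lies behind this step.

The compounds shown do not separate the chloro from the fluoro of the entering aryl. As far as these compounds go, how a sulfonyl aryl carrying an amine or a carboxylic acid, or a longer chain in place of propyl, would read in this assay stays open.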